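Replacing isopropyl with nitro on compound 3

This account rests on a few compounds, and the source may have more. Where it says the series, first, only, none or still open, it means among the compounds named here.

In a functional assay on HCT-116 cells (Homo sapiens) for antiproliferative activity, read by sulforhodamine B assay, with a stated time of 48 h (a higher number here means a weaker inhibitor of growth, a lower number a stronger inhibitor of growth), compound 1 `COc1cccc(Oc2ccc3nc(/C=C/C(=O)NO)ccc3c2)c1` gives 2740 nM, compound 2 `COc1ccc(Oc2ccc3nc(/C=C/C(=O)NO)ccc3c2)cc1` gives 1820 nM and compound 3 `CC(C)c1ccc(Oc2ccc3nc(/C=C/C(=O)NO)ccc3c2)cc1` gives 4080 nM. Compound 3 thus lies within the scatter of compound 1 but beyond it from compound 2. Compound 4 `O=C(/C=C/c1ccc2cc(Oc3ccc([N+](=O)[O-])cc3)ccc2n1)NO` carries nitro in place of isopropyl on an aromatic carbon. Two measured steps offer guidance: a 1.5-fold lower number from compound 1 to compound 2 (0.18 log units; within the scatter) for 4-methoxyphenyl in place of 3-methoxyphenyl, and a 2.2-fold higher number from compound 2 to compound 3 (0.35 log units; beyond the scatter) for isopropyl in place of methoxy. Going by the values given here, both are small, and no nitro compound has been measured yet. A small step towards a lower number, not beyond the scatter, is therefore expected: a 1.6-fold lower number from compound 3 to compound 4 (0.21 log units; within the scatter). The estimate for compound 4 is 2500 nM, with an expected range of 1200 nM to 5000 nM.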

Compound 4, concentration for 50% growth inhibition: 1000 nM
Compound 4: middle estimate off by 2.5-fold (0.40 log units), on the high side, and the stated range ends above it.
By their numbers in this assay, from the lowest: compounds 4, 2, 1 and 3 (each within the scatter of the next, the first and the last beyond it).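

Going by these compounds alone, at this position, on an aromatic carbon para to a large group, the choice of group can move the result beyond the scatter even when the heavy-atom count stays the same: in this assay, nitro in place of isopropyl gives a 4.1-fold lower number from compound 3 to compound 4 (0.61 log units; beyond the scatter) and is the largest step so far. Nitro in place of methoxy gives only a 1.8-fold lower number from compound 2 to compound 4 (0.26 log units; within the scatter) and so does not separate these two groups. No measured evidence here explains the difference between nitro and isopropyl.

On these data alone, whether an amine or a carboxylic acid at this position would give a number like that of nitro remains open. So does how nitro would behave at the position held by methoxy in compound 1.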